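The source may hold more compounds than are shown below. What is called first, only, known or untested is meant among the compounds shown, and "the series" means these compounds.

Of the compounds shown here, three that share one core have already been measured in a functional assay on HCT-116 cells (Homo sapiens) for cytotoxicity, with a stated time of 48 h; on this read-out higher numbers stand for weaker inhibition and lower numbers for stronger inhibition. Compound 1 `COc1cc(O)c(C(=O)/C=C/c2ccc(F)cc2)c(OC)c1` gives 12400 nM. Compound 2 `COc1cc(OC)c(C(=O)/C=C/c2ccc(Cl)cc2)c(OC)c1` gives 5400 nM. Compound 3 `COc1cc(O)c(C(=O)/C=C/c2ccccc2SC)c(OC)c1` gives 10000 nM. Compound 2 thus shows the lowest of the three numbers; its gap to compound 3 stays within the usual scatter, while its gap to compound 1 lies beyond it. Compound 4 `COc1cc(OC)c(C(=O)/C=C/c2ccccc2)c(OC)c1` has not yet been measured. It differs from compound 2 in one place: hydrogen in place of chloro on an aromatic carbon. For the measured compounds named here, no measured pair shows this same change, so its size cannot be read from the numbers at hand. The expected step, a 1.5-fold higher number from compound 2 to compound 4 (0.17 log units; within the scatter), is small, pointing toward a weaker result yet staying within the scatter. Compound 4 is therefore estimated at 8000 nM, within a range from 3000 nM to 25000 nM.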

Compound 4, half-maximal inhibitory concentration: 6900 nM
Compound 4: middle estimate off by 1.2-fold (0.06 log units), on the high side; measured number inside the range.
By their numbers in this assay, from the lowest: compounds 2, 4, 3 and 1 (each within the scatter of the next, the first and the last beyond it).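

In this assay, the change from 4-chlorophenyl to phenyl gives a 1.3-fold higher number from compound 2 to compound 4 (0.11 log units; within the scatter) and stays within the scatter, so the two compounds cannot be told apart. At this place, on an aromatic carbon para to a large group, the chloro group is thus not required for a number at this level. Nothing at hand explains this result. Going by these compounds, whether an amine or a carboxylic acid at this place would shift the number beyond the scatter stays open. So does whether the same change would read alike on the core of compound 1.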